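Trading the Benzodioxin for a Dihydroindole on the Ether Arm

This account rests on a few compounds, and the source may have more. Where it says the series, first, only, none or still open, it means among the compounds named here.

Measured compounds:
Compound 1 `COc1cc(C(=O)n2c(C)c(CC(=O)O)c3ccccc32)ccc1OC[C@@H]1CN(C)c2ccccc2O1` — in a functional assay on CHO cells for antagonist activity at prostaglandin D2 receptor (Mus musculus), read by cAMP accumulation and immunoassay, with a stated time of 10 min, in the presence of a further agent that is not named here (on this read-out higher numbers stand for weaker inhibition and lower numbers for stronger inhibition), compound 1 has "not determined" (no result reported).
Compound 2 `Cc1c(CC(=O)O)c2cc(F)ccc2n1C(=O)c1ccc(OC[C@@H]2CN(C)c3ccccc3O2)cc1Cl` — in this assay compound 2 gives 1.6 nM.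
Compound 3 `Cc1cc(OC[C@@H]2COc3ccccc3O2)ccc1C(=O)n1c(C)c(CC(=O)O)c2ccccc21` — in this assay compound 3 gives 3.8 nM.

Compound 3 therefore holds the higher of the two reported numbers; compound 2 sits lower, and the gap between the two lies beyond the usual scatter of this assay. Compound 4 `Cc1cc(OCC2Cc3ccccc3N2C)ccc1C(=O)n1c(C)c(CC(=O)O)c2ccccc21` differs from compound 3 in one place only: 1-methyl-2,3-dihydro-1H-indol-2-yl in place of 2,3-dihydro-1,4-benzodioxin-2-yl on a saturated chain carbon bound to an oxygen on an aromatic ring. Among the compounds with values here, no measured pair shows this change, so the size and direction of its effect are open; the two reported values carry no direct information about it. The estimate for compound 4 is a step of a 1.6-fold higher number from compound 3 to compound 4 (0.20 log units; within the scatter) that is expected to stay close to the scatter, leaning slightly toward weaker inhibition. Compound 4 is thus expected to give about 6 nM, with a range from 1.5 nM to 25 nM.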

Compound 4, half-maximal inhibitory concentration: 6.2 nM
For compound 4 the middle estimate is 1.0-fold (0.01 log units) below the measured one, and the stated range covers the measured number.
By their numbers in this assay, from the lowest: compound 2; then compounds 3 and 4 (each within the scatter of the next).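

In this assay, placing 1-methyl-2,3-dihydro-1H-indol-2-yl in place of 2,3-dihydro-1,4-benzodioxin-2-yl gives a 1.6-fold higher number from compound 3 to compound 4 (0.21 log units; within the scatter). On a saturated chain carbon bound to an oxygen on an aromatic ring, the six-membered ring with 2 hetero atoms can therefore give way to the five-membered ring with 1 hetero atom, and the step stays within the scatter. Nothing measured here bears on the reason for this result. Still open, going by these compounds, is whether an ethyl group in place of the methyl of the entering group would read alike. Also open, on these data alone, is how the two mirror forms of that group, which has no defined stereocentre, would compare.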